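The source may report more compounds than this note shows. Statements on the series, on what has been measured and on what is new or still open speak of the compounds shown alone.

Measured so far in a functional assay on IMR-32 cells for inhibition of Voltage-dependent N-type calcium channel subunit alpha-1B (Homo sapiens), read by calcium flux; on this read-out lower numbers stand for stronger inhibition and higher numbers for weaker inhibition:
compound 1 `COC(=O)c1cccc(C2C(C(=O)O)=C(C)N=C(C)/C2=C(/O)OC/C=C/c2ccccc2)c1` gives 4600 nM
compound 2 `CC1=NC(C)=C(C(=O)O)C(c2cccc(C)c2)/C1=C(\O)OC/C=C/c1ccccc1` gives 1800 nM
compound 3 `CC1=NC(C)=C(C(=O)O)C(c2cccc(Br)c2)/C1=C(\O)OC/C=C/c1ccccc1` gives 790 nM

Compound 3 stands lowest of the three numbers in this assay. The step of a 2.3-fold lower number from compound 2 to compound 3 (0.36 log units; beyond the scatter) and the step of a 5.8-fold lower number from compound 1 to compound 3 (0.77 log units; beyond the scatter) are both beyond the scatter, so compound 3 shows the strongest inhibition of the three; the step of a 2.6-fold lower number from compound 1 to compound 2 (0.41 log units; beyond the scatter) points the same way.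

Compound 4 `CC1=NC(C)=C(C(=O)O)C(c2cccc(I)c2)/C1=C(\O)OC/C=C/c1ccccc1` differs from compound 3 in one place: iodo in place of bromo on an aromatic carbon. Among the measured compounds shown here, no measured step exchanges one halogen for another. For the measured compounds named here, the steps that touch the same aromatic carbon are a 2.6-fold lower number from compound 1 to compound 2 (0.41 log units; beyond the scatter), a 2.3-fold lower number from compound 2 to compound 3 (0.36 log units; beyond the scatter) and a 5.8-fold lower number from compound 1 to compound 3 (0.77 log units; beyond the scatter), each modest and beyond the scatter, and together they show that the group at this position moves the number in this assay, with bromo giving the lowest value so far. Without a direct halogen-to-halogen comparison, only a small shift in the same direction, or none beyond the scatter, is expected for iodo. The expected step of a 1.3-fold lower number from compound 3 to compound 4 (0.12 log units; within the scatter) is therefore set small. Compound 4 is expected to give 600 nM, with a range from 250 nM to 1500 nM.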

Compound 4, half-maximal inhibitory concentration: 1700 nM
Compound 4: the middle estimate sits 2.8-fold (0.45 log units) below what was measured, outside the stated range (above it).
By their numbers in this assay, from the lowest: compound 3; then compounds 4 and 2 (each within the scatter of the next); then compound 1.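

Among the compounds shown here, the first direct exchange of one halogen for another at this aromatic carbon gives a 2.2-fold higher number from compound 3 to compound 4 (0.33 log units; beyond the scatter) in this assay, so the position distinguishes bromo from iodo, and compound 3 now shows the strongest inhibition of the four. Iodo cannot be told apart from methyl here, at a 1.1-fold lower number from compound 2 to compound 4 (0.02 log units; within the scatter), but it still differs from methoxycarbonyl, with a 2.7-fold lower number from compound 1 to compound 4 (0.43 log units; beyond the scatter), which leaves methoxycarbonyl the weakest of the four groups at this carbon. Nothing on hand explains why bromo and iodo part at this position.

Chloro and fluoro at this carbon, and a phenyl ring with hydrogen there, lie outside the compounds shown, so it remains open whether bromo is the best halogen here or simply the best of the two in hand. From the compounds shown here alone, how a nitrile, an amine or a longer chain at the same carbon would fall relative to bromo, and whether this order of groups would hold on a different side chain of the shared core, also remains open.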